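This account rests on a few compounds, and the source may have more. Where it says the series, first, only, none or still open, it means among the compounds named here.

Three compounds carry measured values. Compound 1 `Nc1nn(C(=O)Nc2ccc(Cc3ccccc3)cc2)c2ccccc12` gives 408 nM in a functional assay on NCI-H460 cells (Homo sapiens) for inhibition, read by sulforhodamine B assay, with a stated time of 48 h; a lower number here means a stronger inhibitor of growth, a higher number a weaker inhibitor of growth. Compound 2 `COc1ccccc1NC(=O)n1nc(N)c2ccccc21`, which keeps the same core, gives 78900 nM in this assay, a gap well beyond the scatter of repeat runs. Compound 3 `COc1ccc(NC(=O)Nc2n[nH]c3ccccc23)cc1` returns only a limit, > 100000 nM in this assay, and (the limit of > 100000 nM in this assay, at which 1 of the 3 values shown sits). Of the two numbers recorded, compound 1 thus stands lowest.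

Compound 4 `CCCCOc1ccc(NC(=O)n2nc(N)c3ccccc32)cc1` has not yet been measured. It differs from compound 1 in one place: butoxy in place of benzyl on an aromatic carbon. Among the measured compounds shown here, no measured pair differs in this single respect, so the size of the step is not fixed by the data. What the neighbours show is that compound 2, on the same core as compound 1, gives a far higher number, while compound 3, built differently around the core, reaches only a limit. In that light the step from compound 1 to compound 4 is expected to be a 3.7-fold higher number from compound 1 to compound 4 (0.57 log units; beyond the scatter), toward weaker inhibition of growth. Compound 4 is therefore estimated at 1500 nM, with a likely range from 300 nM to 8000 nM.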

Compound 4, concentration for 50% growth inhibition: 15700 nM
Estimate against measurement, compound 4: 10-fold (1.02 log units) below; the whole stated range lies below it.
By their numbers in this assay, from the lowest: compound 1; then compound 4; then compound 2. At a limit, above all of these: compound 3.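

Among the compounds shown here, the change from benzyl to butoxy gives a 38-fold higher number from compound 1 to compound 4 (1.59 log units; beyond the scatter) in this assay, and this is the first step that can be read at a single place. It shows that the number at this position, para to a large group, depends strongly on the group that sits there. Butoxy, which has no ring, does not keep the value of compound 1, so the position does not accept any para chain equally. Nothing measured among these compounds accounts for the size of this step.

The compounds shown leave open whether the loss follows the departing ring or the entering oxygen. A phenoxy group or a plain pentyl chain at this place would separate the two.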